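A few compounds are considered here, and "the series" means these few. Any claim that something is new, unique, unknown or untested is made for them only; others in the source may bear on it.

Measured in a functional assay on MIA PaCa-2 cells (Homo sapiens) for antiproliferative activity; on this read-out higher numbers stand for an effect only at larger amounts of compound and lower numbers for an effect already at smaller amounts:
- compound 1 `Cc1cc2c(C(N)=O)cccc2n1-c1nc2c(c(NCc3ccccc3)n1)COCC2`: 146 nM
- compound 2 `CCCC#CC(=O)Nc1cccc2c1cc(C)n2-c1nc2c(c(NCc3ccccc3)n1)CCCC2`: 1570 nM

Compound 1 holds the lower of these two numbers, and the gap up to compound 2 lies beyond the scatter. Compound 3 `C=CC(=O)Nc1cccc2c1cc(C)n2-c1nc2c(c(NCc3ccccc3)n1)COCC2` has not yet been measured. It departs from compound 1 at a single place, with (vinylcarbonyl)amino in place of carbamoyl on an aromatic carbon. For the measured compounds named here, no measured pair differs in just one place, so the data offer no direct guide to this change. The central expectation in this assay is therefore no step beyond the scatter, held with little confidence in either direction. The range stays wide on the upper side, since compound 2 reads 1570 nM. The estimated step is a 1.0-fold higher number from compound 1 to compound 3 (0.01 log units; within the scatter). For compound 3 the expected value is 150 nM, with an estimated range of 25 nM to 900 nM.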

Compound 3, half-maximal effective concentration: 880 nM
The estimate for compound 3 lay 5.9-fold (0.77 log units) below the measured number; the measured number falls inside the stated range.
By their numbers in this assay, from the lowest: compound 1; then compounds 3 and 2 (each within the scatter of the next).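

In this assay, for the compounds shown here, the exchange of carbamoyl for (vinylcarbonyl)amino on an aromatic carbon gives the first single-place comparison in this set, with a 6.0-fold higher number from compound 1 to compound 3 (0.78 log units; beyond the scatter). Going by these compounds alone, this shows that the assay read-out is sensitive to the group at this position of the core of compound 1, which the earlier compounds, differing in more than one place, could not show. No measured evidence accounts for this step.

The compounds shown leave open whether the step follows from the vinyl group itself or from the amide as a whole, which a saturated acyl such as acetylamino at this place would address. Also open, from the compounds shown here alone, is how an amine or a carboxylic acid at this aromatic carbon would read against compound 1 and compound 3.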